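The source may report more compounds than this note shows. Statements on the series, on what has been measured and on what is new or still open speak of the compounds shown alone.

Three compounds have been measured in a functional assay on HeLa cells (Homo sapiens) for inhibition, read by MTT assay, with a stated time of 72 h; on this read-out lower numbers stand for stronger inhibition and higher numbers for weaker inhibition:

compound 1, `CC(C)c1ccc(C(=O)/C=C/C(=O)O)c(C(C)C)c1`, gives 4060 nM
compound 2, `CC(C)c1cc(C(C)C)c(C(=O)/C=C/C(=O)O)c(C(C)C)c1`, gives 6100 nM
compound 3, `CCc1ccc(C(C)C)cc1C(=O)/C=C/C(=O)O`, gives 4890 nM

Compounds 1 and 2 differ in one place: isopropyl in place of hydrogen on an aromatic carbon. That change produced a 1.5-fold higher number from compound 1 to compound 2 (0.18 log units; within the scatter). Compound 3 sits in the same region as both: its value and that of compound 1 lie within the scatter of each other, as do its value and that of compound 2, so no order among the three can be drawn from these numbers. The difference between the core of compound 3 and the core of compound 1 is not broken down here.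

Compound 4, `CCc1c(C(=O)/C=C/C(=O)O)cc(C(C)C)cc1C(C)C`, has not yet been measured. It differs from compound 3 in one place: isopropyl in place of hydrogen on an aromatic carbon. Among the compounds with values here, this is the same kind of change as the one from compound 1 to compound 2, but not the same: in compound 2 the entering group sits ortho to a (2-carboxyethenyl)carbonyl group and meta to two isopropyl groups, whereas in compound 4 it sits ortho to an ethyl group, meta to a (2-carboxyethenyl)carbonyl group and meta to an isopropyl group.

The expectation for compound 4 in this assay rests on a single precedent: because the earlier step was a 1.5-fold higher number from compound 1 to compound 2 (0.18 log units; within the scatter), a step of similar size is expected from compound 3, namely a 1.3-fold higher number from compound 3 to compound 4 (0.12 log units; within the scatter). The surroundings of the entering group differ, so the range is kept wide. Compound 4 is therefore estimated at 6500 nM, with a likely span from 3000 nM to 14000 nM.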

Compound 4, half-maximal inhibitory concentration: 7610 nM
For compound 4 the middle estimate is 1.2-fold (0.07 log units) below the measured one; the measured number falls inside the stated range.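

In this assay, isopropyl in place of hydrogen on an aromatic carbon gave a 1.6-fold higher number from compound 3 to compound 4 (0.19 log units; within the scatter), and this step agrees with the one seen earlier on the core of compound 1: the same change on two cores in this assay, a 1.5-fold higher number (0.18 log units; within the scatter) from compound 1 to compound 2 and a 1.6-fold higher number (0.19 log units; within the scatter) from compound 3 to compound 4, 1.0-fold (0.02 log units) apart, within the scatter of two such steps

So, on these two cores, the change gave steps that cannot be told apart, even though the entering group has different surroundings in each, and in compound 4 it lies ortho to an ethyl group. This does not show that the isopropyl group has any real effect on the read-out, since each step lies within the scatter on its own, and agreement between two small steps is no evidence of a shared effect or a rule for the wider series.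

The ring substituents shown are limited to ethyl and isopropyl groups, so it remains open how a methoxy group, a fluorine atom, an amine or a longer chain such as butyl would read at this place. As far as these compounds go, it also remains open whether an ester or an amide in place of the carboxylic acid would give a step beyond the scatter in this assay.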